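The source may hold more compounds than are shown below. What is called first, only, known or untested is meant among the compounds shown, and "the series" means these compounds.

Measured compounds:
compound 1 `O=C1/C(=C/c2ccc(Cl)cc2Cl)CCCc2ccccc21` gives 407000 nM in a functional assay on CCRF-CEM cells (Homo sapiens) for inhibition; on this read-out higher numbers stand for weaker inhibition and lower numbers for stronger inhibition
compound 2 `O=C1/C(=C/c2ccc(Cl)cc2Cl)CCc2ccccc21` gives 8730 nM in this assay
compound 3 `O=C1/C(=C/c2ccccc2Cl)CCCc2ccccc21` gives 18400 nM in this assay

Compound 3 holds the second highest of the three numbers: compound 2 is beyond the scatter on the lower side, compound 1 far above, as a 22-fold lower number from compound 1 to compound 3 (1.34 log units; beyond the scatter) shows. Compound 4 `O=C1/C(=C/c2ccccc2F)CCCc2ccccc21` is not yet measured; it differs from compound 3 by fluoro in place of chloro on an aromatic carbon. Going by the values given here, only one measured step touches this position, the large one from compound 1 to compound 3, where the chloro was removed altogether. Swapping chloro for fluoro is a smaller change at the same place, so a step in the same direction but of modest size is expected in this assay, likely a 1.8-fold lower number from compound 3 to compound 4 (0.26 log units; within the scatter). Compound 4 is therefore estimated at 10000 nM, with a range of 3000 nM to 40000 nM.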

Compound 4, half-maximal inhibitory concentration: 28200 nM
Beside the measured number, compound 4's estimate is 2.8-fold (0.45 log units) below it, within the range that was stated.
By their numbers in this assay, from the lowest: compound 2; then compounds 3 and 4 (each within the scatter of the next); then compound 1.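

In this assay, a 1.5-fold higher number from compound 3 to compound 4 (0.19 log units; within the scatter) gives the first read on the chloro that compound 3 retains, ortho to a large group: fluoro in its place leaves the two compounds indistinguishable. The large step, a 22-fold lower number from compound 1 to compound 3 (1.34 log units; beyond the scatter), concerned the other chloro of compound 1, so it says nothing about this place. No evidence bears on this result. As far as these compounds go, whether hydrogen, a methoxy group or an amine here would match the two halogens remains open, as does whether this exchange gives the same result on the core of compound 2.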